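The source may hold more compounds than are shown below. What is called first, only, known or untested is meant among the compounds shown, and "the series" means these compounds.

Measured in a functional assay on RAW264.7 cells (Mus musculus) for inhibition, with stated times of 2 h and 24 h (on this read-out lower numbers stand for stronger inhibition and higher numbers for weaker inhibition), each value being a limit and not a number:

Compound 1 `COc1ccc([C@@H]2c3c(OC)cc(OC)cc3C(SCc3ccccc3)[C@H]2c2cc(OC)cc(OC)c2)cc1`: > 200000 nM
Compound 2 `COc1ccc([C@@H]2c3c(OC)cc(OC)cc3C(SCc3ccc(F)cc3)[C@H]2c2cc(OC)cc(OC)c2)cc1`: > 200000 nM
Compound 3 `COc1ccc([C@@H]2c3c(OC)cc(OC)cc3C(C(O)c3ccccc3)[C@H]2c2cc(OC)cc(OC)c2)cc1`: > 200000 nM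

The three compounds share one reading, (the limit of > 200000 nM in this assay, at which 3 of the 3 values shown sit). Compound 3 has no number, only the limit > 200000 nM.

Compound 4 `COc1ccc([C@@H]2c3c(OC)cc(OC)cc3C(C(O)c3ccc(Cl)cc3)[C@H]2c2cc(OC)cc(OC)c2)cc1` differs from compound 3 by chloro in place of hydrogen on an aromatic carbon, para to a large group, turning hydroxy(phenyl)methyl into (4-chlorophenyl)(hydroxy)methyl.

The closest measured change is a step that the two limits leave unreadable from compound 1 to compound 2, which likewise puts a halogen onto an aromatic ring, here fluoro. The other two measured steps, a step that the two limits leave unreadable from compound 1 to compound 3 and a step that the two limits leave unreadable from compound 2 to compound 3, concern the group that carries this ring. None of the three gives a size to carry over, so no direction can be drawn from them.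

The expected outcome is a number no higher from compound 3 to compound 4 (the limit leaves the size open), with nothing beyond the scatter anticipated in this assay. The most likely report is again a limit. For compound 4 the estimated value is 200000 nM, with an expected range of 60000 nM to 400000 nM.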

Compound 4, half-maximal inhibitory concentration: > 200000 nM
Compound 4: a limit, no number (the forecaster's own chance of this, stated with the estimate: 80%); the middle value sits exactly at the limit.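

Compound 4 gives > 200000 nM in this assay, which is a limit and not a number. No step linking compound 4 with compound 1, compound 2 or compound 3 can be read: the limit of > 200000 nM in this assay, at which 4 of the 4 values shown sit.

The compounds shown leave open what number any of these four compounds would reach.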